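A few compounds are considered here, and "the series" means these few. Any claim that something is new, unique, unknown or untested is made for them only; others in the source may bear on it.

Of the compounds shown here, two carry the measured numbers so far. Compound 1 `NC(=O)CC[C@H](NC(=O)CN(c1ncnc2c1ncn2C1CCCCO1)C1CC1)C(=O)OCc1ccccc1` gives 22.3% in a functional assay on the whole organism (Tail, strain ICR) with Mus musculus as the target, in the tail flick test, with a stated time of 120 min, at a dose of 25 umol/kg by the oral route (a higher number here means a stronger effect of the compound at the dose given, a lower number a weaker effect), and compound 2 `CSCC[C@H](NC(=O)CN(c1ncnc2c1ncn2C1CCCCO1)C1CC1)C(=O)OCc1ccccc1` gives 28.7% in the same assay. Among the measured compounds shown here, the one step between them, a number 6.4 percentage points higher from compound 1 to compound 2 (within the scatter), is small enough that the two compounds stand level on this read-out; of the two numbers at hand, that of compound 2 is the one to which compound 3 is compared, with compound 1 the only other point of reference.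

Compound 3 `NC(=O)C[C@H](NC(=O)CN(c1ncnc2c1ncn2C1CCCCO1)C1CC1)C(=O)OCc1ccccc1` is the next case. Its difference from compound 2 reads (carbamoyl in place of (methylsulfanyl)methyl on a saturated chain carbon, two bonds along the chain from an amide-type nitrogen and a carbonyl carbon). For the measured compounds named here, the only measured step that bears on this exchange is the one from compound 1 to compound 2, where the same pair of groups was swapped, cut one bond further out, and the result was a number 6.4 percentage points higher from compound 1 to compound 2 (within the scatter), within the scatter. That step gives no ground for expecting a change beyond the scatter here either. Compound 3 is therefore estimated at 24% in this assay, with a range from 12% to 38%. The step this estimate means, a number 4.7 percentage points lower from compound 2 to compound 3 (within the scatter), is expected to stay within the scatter.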

Compound 3, a percentage reported as activity, at one dose (the size of the read-out at that dose, not a potency): 29.2%
Compound 3: the middle estimate sits 5.2 percentage points below what was measured; measured number inside the range.
By their numbers in this assay, from the lowest: compounds 1, 2 and 3 (each within the scatter of the next).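

In this assay, carbamoyl in place of (methylsulfanyl)methyl on a saturated chain carbon, two bonds along the chain from an amide-type nitrogen and a carbonyl carbon, gives a number 0.5 percentage points higher from compound 2 to compound 3 (within the scatter), so the exchange of these two kinds of group stays within the scatter when cut at this place as well as one bond further out. Carbamoyl in place of carbamoylmethyl at the same place, with the end group kept and the chain length altered, gives a number 6.9 percentage points higher from compound 1 to compound 3 (within the scatter), and this is the first reading of chain length alone in the series: it too stays within the scatter, so compound 1, compound 2 and compound 3 stand level on this read-out. Nothing available on these compounds accounts for this level reading.

Going by these compounds, whether a group of another kind at this place, such as an amine, a carboxylic acid or a longer chain ending in carbamoyl, would give a step beyond the scatter remains open. Also open is whether the level reading holds at other doses and times, since the compounds shown are read at a single dose and a single time.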